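The compounds below may be only part of what the source reports. "The series", "measured", "known", "first", "only" and "open" are said of these compounds alone.

Measured compounds:
Compound 1, `COc1cc(-c2nnc(SCC(=O)c3ccc(Cl)cc3)n2N)cc(OC)c1OC`: in a functional assay on HepG2 cells (Homo sapiens) for antiproliferative activity, read by MTT assay, with a stated time of 48 h (a lower number here means a stronger inhibitor, a higher number a weaker inhibitor), compound 1 gives > 100000 nM, a limit of the assay.
Compound 2, `COc1cc(-c2nnc(SCC(=O)c3ccc(C(F)(F)F)cc3)n2N)cc(OC)c1OC`: in this assay compound 2 gives > 100000 nM, also a limit.
Compound 3, `COc1cc(-c2nnc(SCC(=O)c3ccc(F)c(F)c3)n2N)cc(OC)c1OC`: in this assay compound 3 gives > 100000 nM, again a limit.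

Compound 1 therefore stands only at a limit, and no ordering among the three is readable, since (the limit of > 100000 nM in this assay, at which 3 of the 3 values shown sit). The steps a step that the two limits leave unreadable from compound 1 to compound 2, a step that the two limits leave unreadable from compound 1 to compound 3 and a step that the two limits leave unreadable from compound 2 to compound 3 stay unreadable in size. Compound 4, `COc1cc(-c2nnc(SCC(=O)c3ccccc3F)n2N)cc(OC)c1OC`, differs from compound 1 by 2-fluorophenyl in place of 4-chlorophenyl on a carbonyl carbon. The measured steps bearing on it, all exchanges of the aryl on the carbonyl carbon, show no readable change, so no step beyond the scatter is expected in this assay. Compound 4 is estimated at 150000 nM (range 30000 nM to 600000 nM), an expected step that the limit leaves unreadable from compound 1 to compound 4.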

Compound 4, half-maximal inhibitory concentration: 22600 nM
Compound 4: middle estimate off by 6.6-fold (0.82 log units), on the high side, and the stated range ends above it.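

The aryl on the carbonyl carbon is therefore not a silent place in this assay: exchange for 2-fluorophenyl gives an at least 4.4-fold lower number from compound 1 to compound 4 (0.64 log units; beyond the scatter), an at least 4.4-fold lower number from compound 3 to compound 4 (0.64 log units; beyond the scatter) and an at least 4.4-fold lower number from compound 2 to compound 4 (0.64 log units; beyond the scatter). Each of these sizes is only a lower bound, because the three partner compounds rest at a limit: the limit of > 100000 nM in this assay, at which 3 of the 4 values shown sit. Fluorine on the ring is not enough by itself: compound 3, with 3,4-difluorophenyl, stays at > 100000 nM, a limit. The compounds shown leave open whether the lower number needs fluorine at all, and whether an unsubstituted phenyl or a phenyl bearing an amine would reach it too.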